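The source may report more compounds than this note shows. Statements on the series, on what has been measured and on what is new or still open speak of the compounds shown alone.

Measured compounds:
compound 1, `CCCCOc1ccc(-c2nc3ncccn3c2N)cc1`, > 100000 nM
compound 2, `CCCCOc1ccc(-c2nc3ncccn3c2Nc2ccc(F)cc2)cc1`, > 100000 nM
compound 3, `Fc1ccc(COc2ccc(-c3nc4ncccn4c3NC3CCCCC3)cc2)cc1`, 24000 nM

All three were tested in a toxicity assay on A549 cells (Homo sapiens) for cytotoxicity, read by luminescence and CellTiter-Glo, with a stated time of 48 h; on this read-out higher numbers stand for lower toxicity in this test and lower numbers for higher toxicity in this test. For compound 1 the value > 100000 nM is a limit of the assay, not a number. For compound 2 the value > 100000 nM is likewise a limit. For the measured compounds named here, compound 3 gives 24000 nM in this assay, the only number among the three; the other two values sit at the limit of > 100000 nM in this assay, at which 2 of the 3 values shown sit. The step that the two limits leave unreadable from compound 1 to compound 2 is therefore of unknown size.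

Compound 4, `COc1ccc(-c2nc3ncccn3c2NC2CCCCC2)cc1`, keeps the cyclohexylamine of compound 3 and differs from it only in hydrogen in place of 4-fluorophenyl on a saturated chain carbon bound to an oxygen on an aromatic ring. Going by the values given here, no measured step touches that part of the molecule: the single measured step concerns the substituent on the ring nitrogen, and even that one cannot be read. The expectation for compound 4 thus rests on compound 3 alone, together with the fact that two of the three compounds reach the limit in this assay. Compound 4 is expected to show a 2.5-fold higher number from compound 3 to compound 4 (0.40 log units; beyond the scatter), a modest step toward lower toxicity in this assay, close to the edge of the scatter. Compound 4 is therefore estimated at 60000 nM, with a range from 20000 nM to 200000 nM.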

Compound 4, half-maximal cytotoxic concentration: > 100000 nM
Compound 4: a limit, no number; the forecaster's own chance of this, stated with the estimate: 40%; middle value at least 1.6-fold (0.22 log units) from the limit.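

Cutting 4-fluorobenzyl back to methyl on the oxygen, with the cyclohexylamine left unchanged, gives an at least 4.1-fold higher number from compound 3 to compound 4 (0.61 log units; beyond the scatter) in this assay, the first step in this set that can be read. Compound 4 gives > 100000 nM, which is a limit of the assay and not a number. Of this pair, only the compound carrying the 4-fluorophenyl gives a number, so a change at this place can move the read-out, but the full size of the step stays unknown, and the assay gives few numbers to compare: the limit of > 100000 nM in this assay, at which 3 of the 4 values shown sit.

The compounds shown leave open whether the step comes from the fluorine, from the aromatic ring or simply from the length of the group, and a plain benzyl group or a hexyl chain on that oxygen would bear on this question. From the compounds shown here alone, the step from compound 1 to compound 2 cannot be read, so what the group on the nitrogen contributes to the number of compound 3 also stays open.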